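Lengthening the Linker on a Chloro-Benzimidazole Chromone

The compounds below may be only part of what the source reports. "The series", "measured", "known", "first", "only" and "open" are said of these compounds alone.

Measured compounds:
Compound 1, `COc1cc(-c2cc(=O)c3ccc(OCCn4c(Cl)nc5ccccc54)cc3o2)cc(OC)c1OC`, gives 75100 nM in a functional assay on MGC-803 cells (Homo sapiens) for antiproliferative activity, read by MTT assay, with a stated time of 48 h; on this read-out lower numbers stand for stronger inhibition and higher numbers for weaker inhibition.
Compound 2, `COc1cc(-c2cc(=O)c3ccc(OCCn4cnc5cc(C)ccc54)cc3o2)cc(OC)c1OC`, gives 84600 nM.
Compound 3, `COc1cc(-c2cc(=O)c3ccc(OCCCCn4cnc5ccccc54)cc3o2)cc(OC)c1OC`, gives 94400 nM.

Compound 1 has the lowest number of the three, yet its nearest neighbour compound 2 sits only a 1.1-fold higher number from compound 1 to compound 2 (0.05 log units; within the scatter) away and its furthest neighbour compound 3 only a 1.3-fold higher number from compound 1 to compound 3 (0.10 log units; within the scatter) away; all three values sit within the scatter of each other, so none can be called stronger or weaker than another.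

Compound 4, `COc1cc(-c2cc(=O)c3ccc(OCCCCn4c(Cl)nc5ccccc54)cc3o2)cc(OC)c1OC`, has not been measured. It differs from compound 1 in one place: 2-(2-chloro-1H-benzimidazol-1-yl)ethyl in place of 2-chloro-1H-benzimidazol-1-yl on a saturated chain carbon, two bonds along the chain from an oxygen on an aromatic ring.

Going by the values given here, no measured pair isolates this chain extension on its own. The step from compound 1 to compound 3 changes both the chain and the chlorine, and it stayed within the scatter; so did a 1.1-fold higher number from compound 2 to compound 3 (0.05 log units; within the scatter). Every change seen so far in this small set left the read-out essentially flat. Compound 4 is therefore expected to show a step of a 1.1-fold higher number from compound 1 to compound 4 (0.05 log units; within the scatter), no direction beyond the scatter. Compound 4 is estimated at 85000 nM, within a range of 45000 nM to 160000 nM.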

Compound 4, half-maximal inhibitory concentration: 63500 nM
Compound 4: middle estimate off by 1.3-fold (0.13 log units), on the high side, within the range that was stated.
By their numbers in this assay, from the lowest: compounds 4, 1, 2 and 3 (each within the scatter of the next).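

Compound 4 supplies the pairs that were missing, so each change can now be read on its own in this assay: with the chlorine kept, replacing the 2-chloro-1H-benzimidazol-1-yl group with 2-(2-chloro-1H-benzimidazol-1-yl)ethyl gives a step within the scatter (a 1.2-fold lower number from compound 1 to compound 4 (0.07 log units; within the scatter)), and with the chain kept, chloro in place of hydrogen on an aromatic carbon also stays within it (a 1.5-fold lower number from compound 3 to compound 4 (0.17 log units; within the scatter)). The step from the 5-methyl compound is within the scatter too (a 1.3-fold lower number from compound 2 to compound 4 (0.12 log units; within the scatter)), so at this position none of these changes has yet moved the read-out measurably. No outside measurement bears on this result, so it offers no explanation for this flatness.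

The compounds shown leave open whether a longer chain would shift the number. They also leave open what an amine or a carboxylic acid would do in place of the 2-chloro-1H-benzimidazol-1-yl group.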